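This account rests on a few compounds, and the source may have more. Where it says the series, first, only, none or still open, it means among the compounds named here.

Compound 2 `COc1ccc(Cn2c(C)cc(OCc3ccc(F)cc3F)cc2=O)cc1` stands only at a limit in an ADME assay on Vero cells (Chlorocebus sabaeus) for cytotoxicity; on this read-out lower numbers stand for higher toxicity in this test and higher numbers for lower toxicity in this test: it reads < 4600 nM, and no exact number is known. Compound 1 `Cc1cc(OCc2ccc(F)cc2F)cc(=O)n1Cc1ccc(C(F)(F)F)cc1` reads < 4800 nM, which is also a limit. Among the measured compounds shown here, the one measured step that bears on what follows is a step that the two limits leave unreadable from compound 1 to compound 2, and it swaps methoxy for trifluoromethyl on an aromatic carbon. Compound 3 `Cc1cc(OCc2ccc(F)cc2F)cc(=O)n1Cc1ccc(-c2ccccc2)cc1` differs from compound 2 by phenyl in place of methoxy on an aromatic carbon, para to a large group: phenyl in place of methoxy on an aromatic carbon. The step that the two limits leave unreadable from compound 1 to compound 2 gives no size to carry over, so no step beyond the usual scatter is expected in this assay, and no firm direction can be expected either. The expected change is a step that the limit leaves unreadable from compound 2 to compound 3. Compound 3 is estimated at 3500 nM, with an expected range from 1200 nM to 6000 nM, and it may well come back as a limit again.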

Compound 3, half-maximal cytotoxic concentration: 10000 nM
Beside the measured number, compound 3's estimate is 2.9-fold (0.46 log units) below it; the whole stated range lies below it.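

In this assay, phenyl in place of methoxy on this aromatic carbon gives an at least 2.1-fold higher number from compound 2 to compound 3 (0.33 log units; beyond the scatter), and phenyl in place of trifluoromethyl gives an at least 2.0-fold higher number from compound 1 to compound 3 (0.31 log units; beyond the scatter). Unlike the unreadable step between the two earlier compounds, these steps show that the group at this position can shift the read-out beyond the scatter, here towards lower toxicity in this test. Compound 2 stands only at a limit: the limit of < 4600 nM in this assay, at which 1 of the 3 values shown sits.

Among the compounds shown here, compound 1 also stands only at a limit, which leaves the true size of both steps open: the limit of < 4800 nM in this assay, at which 1 of the 3 values shown sits. It also remains open whether an amine or a carboxylic acid at this position would give a number near that of compound 3 or one closer to the limits of the earlier compounds.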